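The source may hold more compounds than are shown below. What is called first, only, known or untested is meant among the compounds shown, and "the series" means these compounds.

Working notes on the series built on the shared core of compound 1 `CCC(=O)NC[C@@H]1CC1c1cccc2oc(CCCCc3ccccc3)cc12`. For the measured compounds named here, in an assay on NIH3T3 cells for binding affinity to melatonin receptor type 1B (Homo sapiens) (on this read-out higher numbers stand for weaker inhibition and lower numbers for stronger inhibition), compound 1 gives 2.8 nM, the lowest of the two numbers measured so far; compound 2 `O=C(NC[C@@H]1CC1c1cccc2oc(CCCCc3ccccc3)cc12)C1CC1` gives 33 nM, the step of a 12-fold higher number from compound 1 to compound 2 (1.07 log units; beyond the scatter) following cyclopropyl in place of ethyl on a carbonyl carbon. Compound 3 `CC(=O)NCCCc1cccc2oc(CCCCc3ccccc3)cc12` differs from compound 1 at another place: 3-acetamidopropyl in place of 2-((propanoylamino)methyl)cyclopropyl on an aromatic carbon. Going by the values given here, the one measured step does not touch this position and so bears on it only loosely, showing that a single change elsewhere moved this assay beyond the scatter. For compound 3 a step of a 4.3-fold higher number from compound 1 to compound 3 (0.63 log units; beyond the scatter) toward a higher number is expected. The estimate for compound 3 is 12 nM, within 2.5 nM to 60 nM.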

Compound 3, inhibition constant: 127 nM
For compound 3 the middle estimate is 11-fold (1.02 log units) below the measured one, outside the stated range (above it).
By their numbers in this assay, from the lowest: compound 1; then compound 2; then compound 3.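

The aromatic carbon carrying this side chain is sensitive in this assay: a 45-fold higher number from compound 1 to compound 3 (1.66 log units; beyond the scatter) accompanies 3-acetamidopropyl in place of 2-((propanoylamino)methyl)cyclopropyl. This single exchange removes the three-membered ring and the defined stereocentre and also replaces propanoylamino with acetamido, so the step cannot be assigned to any one of these differences. Nothing available explains the step.

Still open, from the compounds shown here alone, is how a 3-(propanoylamino)propyl group on the same aromatic carbon would read, which would separate the loss of the ring from the change in the acyl group.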